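A few compounds are considered here, and "the series" means these few. Any claim that something is new, unique, unknown or untested is made for them only; others in the source may bear on it.

Measured in a functional assay (QGY7701 cells, Homo sapiens) for inhibition, read by MTT assay, with a stated time of 48 h; on this read-out higher numbers stand for weaker inhibition and lower numbers for stronger inhibition:
- compound 1 `Cc1ccc(CNC(=O)/C=C/c2coc3cc(O)ccc3c2=O)cc1` gives 24900 nM
- compound 2 `COc1ccc2c(=O)c(/C=C/C(=O)NCc3ccc(F)cc3F)coc2c1` gives > 100000 nM, a limit and not a number

Compound 2 stands at the limit of > 100000 nM in this assay, at which 1 of the 2 values shown sits, so no number fixes its place in the series. Compound 3 `O=C(/C=C/c1coc2cc(O)ccc2c1=O)NCc1ccc(F)cc1F` differs from compound 2 by hydrogen in place of methyl on an oxygen on an aromatic ring, methoxy to hydroxy. Compound 1 also carries the hydroxy and gives 24900 nM, so compound 3 is expected to land in that region, though compound 1 differs elsewhere too. The expected change is a clear step toward stronger inhibition, estimated as an at least 2.8-fold lower number from compound 2 to compound 3 (0.45 log units; beyond the scatter). For compound 3 the estimated value is 35000 nM, with an expected range of 12000 nM to 100000 nM.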

Compound 3, half-maximal inhibitory concentration: > 100000 nM
Compound 3 ended at the assay's limit; the forecaster's own chance of this, stated with the estimate: 20%; at least 2.8-fold (0.45 log units) between middle value and limit.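

With the hydroxy held fixed, 2,4-difluorophenyl in place of 4-methylphenyl on the saturated chain carbon reads in this assay as an at least 4.0-fold higher number from compound 1 to compound 3 (0.60 log units; beyond the scatter). The hydroxy alone therefore does not bring a compound of this series inside the measurable range. The step from methoxy to hydroxy cannot be read, as compound 2 and compound 3 both stand at a limit and not at a number: the limit of > 100000 nM in this assay, at which 2 of the 3 values shown sit.

Going by these compounds, how the methoxy form of compound 1 reads stays open. So does the effect of a single fluorine, or of an amine or a carboxylic acid, on that phenyl ring.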